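The source may report more compounds than this note shows. Statements on the series, on what has been measured and on what is new or still open speak of the compounds shown alone.

Compound 2 `C/C(=C\C(=O)Nc1ccccc1OCCCC(=O)O)c1ccc2c(ccn2C(C(C)C)C(C)C)c1` gives 14 nM in an assay on Prostate gland for inhibition of steroid 5-alpha-reductase (Rattus norvegicus) (on this read-out higher numbers stand for weaker inhibition and lower numbers for stronger inhibition), the lower of the two numbers at hand. Compound 1 `CCC(C)n1ccc2cc(/C(C)=C/C(=O)Nc3ccccc3OCCCC(=O)O)ccc21` gives 67 nM in this assay. Among the compounds with values here, the one step between them, a 4.8-fold lower number from compound 1 to compound 2 (0.68 log units; beyond the scatter), came from enlarging the group on the aromatic nitrogen. Compound 3 `CCCCc1ccc(Cn2ccc3cc(/C(C)=C/C(=O)Nc4ccccc4OCCCC(=O)O)ccc32)cc1` changes that same position again: 4-butylbenzyl in place of 1-isopropyl-2-methylpropyl on an aromatic nitrogen. Within the data shown here, only that one step bears on it, and it points toward a larger group giving a lower number, though the entering group here carries a ring. Compound 3 is therefore expected to show a 1.4-fold lower number from compound 2 to compound 3 (0.15 log units; within the scatter), an estimated 10 nM with a range from 3 nM to 40 nM.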

Compound 3, half-maximal inhibitory concentration: 100 nM
Compound 3: middle estimate off by 10-fold (1.00 log units), on the low side; measured number outside the range, above it.
By their numbers in this assay, from the lowest: compound 2; then compounds 1 and 3 (each within the scatter of the next).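

Heavy-atom count alone does not set the number at this position on the aromatic nitrogen: 4-butylbenzyl has more heavy atoms than 1-isopropyl-2-methylpropyl, yet the change gives a 7.1-fold higher number from compound 2 to compound 3 (0.85 log units; beyond the scatter). The comparison with sec-butyl reads a 1.5-fold higher number from compound 1 to compound 3 (0.17 log units; within the scatter), so those two numbers cannot be told apart. The earlier link between a larger group and a lower number therefore does not hold for compound 3.

Nothing at hand gives a reason for this result. On these data alone, it remains open whether the ring or the butyl chain matters, and a plain benzyl or cyclohexylmethyl group on this nitrogen would help separate them.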